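The source may hold more compounds than are shown below. What is called first, only, known or untested is meant among the compounds shown, and "the series" means these compounds.

Of the compounds shown here, two of the shared core have been measured in an in vitro assay on HEK385-7 cells for displacement of a labelled ligand from prostaglandin D2 receptor 2 (Homo sapiens); a higher number here means a weaker inhibitor, a lower number a stronger inhibitor. Compound 1, `O=C(O)Cc1sc(NC(=O)c2ccccc2)nc1-c1ccc(Cl)cc1`, gives 520 nM in this assay. Compound 2, `O=C(O)Cc1sc(C(c2ccc(F)cc2)c2ccc(F)cc2)nc1-c1ccoc1`, gives 14 nM in this assay, the lower of the two numbers; the gap from compound 1 to compound 2 lies well beyond the scatter, and compound 2 stands as the stronger inhibitor of the pair. For the measured compounds named here, the two differ in more than one place, so no single step between them is set out, and only their two values can be compared.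

Compound 3, `Nc1cc(-c2nc(C(c3ccc(F)cc3)c3ccc(F)cc3)sc2CC(=O)O)cc(F)n1`, has not yet been measured. It differs from compound 2 in one place: 2-amino-6-fluoropyridin-4-yl in place of furan-3-yl on an aromatic carbon. Going by the values given here, no measured pair shows this change, so its effect is unknown here. The expectation is that the step of a 1.4-fold higher number from compound 2 to compound 3 (0.15 log units; within the scatter) will be small, with no clear direction, and may well stay within the scatter of repeated measurements. On that basis compound 3 is estimated to give 20 nM in this assay, with a range from 6 nM to 70 nM.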

Compound 3, half-maximal inhibitory concentration: 220 nM
Estimate against measurement, compound 3: 11-fold (1.04 log units) below; the measured number lies above the stated range.
By their numbers in this assay, from the lowest: compound 2; then compound 3; then compound 1.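

The only single-place step shown at this position makes clear that the aromatic carbon next to the ring nitrogen, and next to the ring atom that bears a carboxymethyl group, is not indifferent to the group it carries: in this assay, 2-amino-6-fluoropyridin-4-yl in place of furan-3-yl gives a 16-fold higher number from compound 2 to compound 3 (1.20 log units; beyond the scatter), with the rest of the molecule unchanged. The exchange of this five-membered aromatic ring for a six-membered one bearing an amine and a fluorine atom therefore costs clearly more than the scatter, so a larger aromatic group with these added atoms is not interchangeable with furan-3-yl here. Nothing in the data shown accounts for this loss.

This single step changes the ring, the amine and the fluorine together, so the compounds shown leave open which of these carries the loss. An unsubstituted pyridin-4-yl, a 2-aminopyridin-4-yl and a 2-fluoropyridin-4-yl group at this same position would pull those changes apart, and a phenyl group would show how a six-membered ring without a ring nitrogen compares with furan-3-yl.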